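The source may report more compounds than this note shows. Statements on the series, on what has been measured and on what is new or still open speak of the compounds shown alone.

Compound 1 `CCCC1Nc2cccc([C@@H]3C[C@H]3CNC(=O)C(C)C)c2O1`: 0.28 nM
Compound 2 `CCCC1Nc2cccc([C@@H]3C[C@H]3CNC(=O)C3CC3)c2O1`: 0.14 nM

In an assay on NIH3T3 cells with melatonin receptor type 1B (Homo sapiens) as the target (a lower number here means a stronger inhibitor, a higher number a weaker inhibitor), compound 2 gives the lowest of the two numbers; its nearest neighbour is compound 1, and the step of a 2.0-fold lower number from compound 1 to compound 2 (0.30 log units; within the scatter) falls within the usual scatter, so the two cannot be ordered. Compound 3 `CCCC1Nc2cccc([C@@H]3C[C@H]3CNC(=O)NCC)c2O1` differs from compound 2 in one place: ethylamino in place of cyclopropyl on a carbonyl carbon. Among the compounds with values here, the only measured step that touches this position is a 2.0-fold lower number from compound 1 to compound 2 (0.30 log units; within the scatter), a swap of one small carbon group for another on the same carbonyl carbon, and it stayed within the scatter. Within the data shown here, the present change is of a different kind, since a hydrogen-bond donor enters where none was, and no measured pair shows what that does here. A modest rise in the number is therefore expected, with wide uncertainty, giving a 4.3-fold higher number from compound 2 to compound 3 (0.63 log units; beyond the scatter). Compound 3 is expected to give about 0.6 nM, in the range 0.15 nM to 2.5 nM.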

Compound 3, inhibition constant: 1 nM
Estimate against measurement, compound 3: 1.7-fold (0.22 log units) below, within the range that was stated.
By their numbers in this assay, from the lowest: compounds 2 and 1 (each within the scatter of the next); then compound 3.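

In this assay, ethylamino on the carbonyl carbon gives a 7.1-fold higher number from compound 2 to compound 3 (0.85 log units; beyond the scatter) and a 3.6-fold higher number from compound 1 to compound 3 (0.55 log units; beyond the scatter) in the same direction, so this position responds to a change that the earlier swap of small carbon groups did not reveal. Isopropyl has no ring, so the rise against it shows that the loss of the cyclopropyl ring is not needed for the number to go up; what does enter in both steps is a hydrogen-bond donor. No evidence at hand explains the rise.

The compounds shown leave open how a propyl chain or an ethoxy group on the same carbonyl carbon would compare with ethylamino. Such a comparison would show whether the rise follows the hydrogen-bond donor or some other feature of ethylamino.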